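The source may report more compounds than this note shows. Statements on the series, on what has been measured and on what is new or still open speak of the compounds shown alone.

Working notes on the series in a functional assay on KYSE-450 cells (Homo sapiens) for inhibition, read by MTT assay, with a stated time of 48 h; a lower number here means a stronger inhibitor, a higher number a weaker inhibitor.

Of the compounds shown here, three have numbers so far. Compound 1 `CCC/C=C/C(=O)N(Cc1ccc(OC)c(O)c1)c1cc(OC)c(OC)c(OC)c1` gives 57 nM in this assay, the lowest of the three. Compound 3 `C/C=C/C(=O)N(Cc1ccc(OC)c(N)c1)c1cc(OC)c(OC)c(OC)c1` gives 310 nM, and the gap between compound 1 and compound 3 lies beyond the scatter. Compound 2 `COc1ccc(CNc2cc(OC)c(OC)c(OC)c2)cc1[N+](=O)[O-]` gives 16800 nM, far above both, also beyond the scatter. Compound 1 thus stands at the strong end of what has been measured here.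

Compound 4 `COc1ccc(CN(C(=O)CCCCCl)c2cc(OC)c(OC)c(OC)c2)cc1O` has not yet been measured. It differs from compound 1 in one place: 4-chlorobutyl in place of pent-1-en-1-yl on a carbonyl carbon. Going by the values given here, no step between measured compounds covers this kind of change, so the direction rests on the shared core alone, which holds the two strongest numbers in compound 1 and compound 3.

The expectation is a moderate weakening, with the step from compound 1 to compound 4 in this assay estimated as a 2.6-fold higher number from compound 1 to compound 4 (0.42 log units; beyond the scatter). Compound 4 is estimated at 150 nM, within a range of 40 nM to 600 nM.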

Compound 4, half-maximal inhibitory concentration: 770 nM
Compound 4: middle estimate off by 5.1-fold (0.71 log units), on the low side; the measured number lies above the stated range.
By their numbers in this assay, from the lowest: compound 1; then compound 3; then compound 4; then compound 2.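

In this assay, the group on the carbonyl carbon proves to be a sensitive place in the core of compound 1: 4-chlorobutyl in place of pent-1-en-1-yl gives a 14-fold higher number from compound 1 to compound 4 (1.13 log units; beyond the scatter). Going by these compounds alone, the size of this step stands out, as the two groups have the same number of heavy atoms, neither has a ring, and neither has hydrogen-bond donors or acceptors; no step among the earlier compounds covered this place. Nothing measured here explains the rise in the number.

The change removes the double bond and brings in the chlorine in a single step, so the contribution of each remains unresolved. As far as these compounds go, a saturated pentyl chain on the same carbonyl carbon would separate the two, and whether a longer chain is tolerated also remains open.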